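A few compounds are considered here, and "the series" means these few. Any claim that something is new, unique, unknown or untested is made for them only; others in the source may bear on it.

Measured in an ADME assay on cells (Hepatocyte, Homo sapiens) for metabolic stability; a lower number here means that the compound disappears faster, a higher number that the compound lasts longer:
- Compound 1 `O=c1cc(N2CCN(CC3CCC(NS(=O)(=O)c4ccccc4)CC3)CC2)sc2c([N+](=O)[O-])cc(C(F)(F)F)cc12`: > 1.55 h (a limit)
- Compound 2 `Cc1ccc(C(=O)OC2CCC(CN3CCN(c4cc(=O)c5cc(C(F)(F)F)cc([N+](=O)[O-])c5s4)CC3)CC2)cc1`: 0.148 h
- Compound 3 `CC(=O)OC1CCC(CN2CCN(c3cc(=O)c4cc(C(F)(F)F)cc([N+](=O)[O-])c4s3)CC2)CC1`: < 0.15 h (a limit)

Compound 3 sits at the low end of these numbers, together with compound 2, and far from compound 1. Compound 3 gives < 0.15 h, which is a limit of the assay and not a number.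

Two large steps set this picture. With acetoxy in place of (phenylsulfonyl)amino on a saturated ring carbon there is an at least 10-fold lower number from compound 1 to compound 3 (1.01 log units; beyond the scatter). With ((4-methylphenyl)carbonyl)oxy in that place there is an at least 10-fold lower number from compound 1 to compound 2 (1.02 log units; beyond the scatter). The step that swaps methyl for 4-methylphenyl on a carbonyl carbon is a step that the limit leaves unreadable from compound 2 to compound 3, so the data do not show what such a swap does.

Compound 4 `O=C(OC1CCC(CN2CCN(c3cc(=O)c4cc(C(F)(F)F)cc([N+](=O)[O-])c4s3)CC2)CC1)c1ccc(F)cc1` differs from compound 3 by one change: 4-fluorophenyl in place of methyl on a carbonyl carbon. In words, 4-fluorophenyl takes the place of methyl on a carbonyl carbon, turning acetoxy into ((4-fluorophenyl)carbonyl)oxy. Its closest measured relative is compound 2, with 4-methylphenyl on that carbonyl carbon and a value of 0.148 h, so compound 4 is expected to stay in the same low region. The expected change is a step that the limit leaves unreadable from compound 3 to compound 4, and no step beyond the scatter is expected. For compound 4 the estimated half-life is 0.14 h, with an expected range from 0.07 h to 0.3 h.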

Compound 4, half-life: 0.0983 h
Beside the measured number, compound 4's estimate is 1.4-fold (0.15 log units) above it; the range from low to high includes it.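

With fluoro in place of methyl on an aromatic carbon, this assay shows a 1.5-fold lower number from compound 2 to compound 4 (0.18 log units; within the scatter), so these two aromatic esters cannot be told apart, while exchanging the whole group on the saturated ring carbon gives an at least 15-fold lower number from compound 1 to compound 4 (1.19 log units; beyond the scatter). That large step is a minimum, since compound 1 stands at a limit of the assay and not at a number: the limit of > 1.55 h in this assay, at which 1 of the 4 values shown sits. The step from compound 3 to compound 4 cannot be read, because compound 3 also stands at a limit: the limit of < 0.15 h in this assay, at which 1 of the 4 values shown sits.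

Compound 2, compound 3 and compound 4 all carry an ester on the saturated ring carbon and all sit low, but compound 1 differs from them there in the whole group, so the compounds shown leave open whether the ester link itself goes with the short half-life or whether the (phenylsulfonyl)amino group goes with the long one. An amide carrying the same 4-fluorophenyl group, or a plain hydroxyl or amine on that carbon, would help to separate these two readings.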